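Compound 2 to compound 4: one ring exchanged

This account rests on a few compounds, and the source may have more. Where it says the series, first, only, none or still open, it means among the compounds named here.

- compound 1 `O=C(NO)c1cc(F)c(Cn2nnc(-c3ccco3)n2)c(F)c1` gives 100%
- compound 2 `Cn1c(Sc2c(F)cc(C(=O)NO)cc2F)nnc1-c1cccs1` gives 99%
- compound 3 `O=C(NO)c1ccc(Cn2nnc(-c3ncccn3)n2)cc1` gives 76%

All three values come from an ADME assay on a cell-free system (plasma, Homo sapiens) for metabolic stability, read by LC-MS, with a stated time of 4 h, tested at 100 uM; on this read-out higher numbers stand for a more stable compound and lower numbers for a less stable compound. In this set, compound 2 at 99% stands within the usual scatter of compound 1, while compound 3 lies below both, beyond the scatter of compound 2.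

Compound 4 `Cc1cc(-c2nnc(Sc3c(F)cc(C(=O)NO)cc3F)n2C)nn1C` differs from compound 2 in one place, with 1,5-dimethyl-1H-pyrazol-3-yl in place of thiophen-2-yl on an aromatic carbon.

For the measured compounds named here, no measured pair shows this exchange or any other single change, so the three values offer only a loose guide. Compound 1 remains at 100%, whereas compound 3 reaches 76%, so a fall cannot be ruled out. The expected change is a number 4 percentage points lower from compound 2 to compound 4 (within the scatter), a small fall that would stay within the scatter. For compound 4 the estimate is 95%, with an expected range from 80% to 100%.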

Compound 4, percent of the compound remaining: 92%
For compound 4 the middle estimate is 3 percentage points above the measured one; the measured number falls inside the stated range.
By their numbers in this assay, from the lowest: compound 3; then compounds 4, 2 and 1 (each within the scatter of the next).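

In this assay, for the compounds shown here, the exchange of thiophen-2-yl for 1,5-dimethyl-1H-pyrazol-3-yl gives the first step in this set that can be read at a single place, a number 7 percentage points lower from compound 2 to compound 4 (within the scatter) on the aromatic carbon between two ring nitrogen atoms. At this position, therefore, the read-out stays within the scatter when a ring with one hetero atom, sulfur, gives way to a ring with two nitrogen atoms and two added methyl groups. The data offer no explanation for this result.

The compounds shown leave open how this position would read with a group of another kind, such as an amine or a carboxylic acid. They also leave open whether the same exchange would give a similar step on the core of compound 1.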